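The source may report more compounds than this note shows. Statements on the series, on what has been measured and on what is new or still open speak of the compounds shown alone.

Compound 2 `CSc1cnc2ccccc2c1SCC#CCOC(=O)c1ccccc1` sits second highest among the three numbers obtained so far in a functional assay on CCRF-CEM cells (Homo sapiens) for antiproliferative activity, with a stated time of 72 h; on this read-out higher numbers stand for weaker inhibition and lower numbers for stronger inhibition. Compound 2 gives 22.2 ug/mL in this assay. Its nearest neighbour is compound 3 `C#CCSc1cnc2ccccc2c1SCC#CCOC(=O)/C=C/c1ccccc1`, which gives 50.9 ug/mL; the furthest is compound 1 `CSc1cnc2ccccc2c1SCC#CCO`, which gives 2.3 ug/mL. Going by the values given here, the only step measured between two compounds that differ in one place is a 9.7-fold higher number from compound 1 to compound 2 (0.98 log units; beyond the scatter), and it concerns the same oxygen on the saturated carbon that compound 4 keeps.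

Compound 4 `CSc1cnc2ccccc2c1SCC#CCOC(=O)c1ccc(C(=O)O)cc1` differs from compound 2 by carboxy in place of hydrogen on an aromatic carbon. Among the compounds with values here, no measured pair shows what adding a carboxy group does here; the step of compound 3 beside compound 2 changes other parts of the molecule. The step from compound 1 to compound 2 tells only how much the benzoyl ester itself shifted the number in this assay.

Within the data shown here, with no direct precedent, the number for compound 4 is expected to stay close to that of compound 2, perhaps drifting slightly higher, a step of a 1.4-fold higher number from compound 2 to compound 4 (0.13 log units; within the scatter). Compound 4 is therefore estimated at 30 ug/mL, with a range from 12 ug/mL to 75 ug/mL.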

Compound 4, concentration for 50% inhibition: 14.5 ug/mL
Compound 4: the middle estimate sits 2.1-fold (0.32 log units) above what was measured; the range from low to high includes it.
By their numbers in this assay, from the lowest: compound 1; then compounds 4 and 2 (each within the scatter of the next); then compound 3.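

Carboxy on an aromatic carbon, para to a large group, turns phenyl into 4-carboxyphenyl and gives a 1.5-fold lower number from compound 2 to compound 4 (0.18 log units; within the scatter) in this assay. Going by these compounds alone, this is the first measured change on the aromatic ring of the ester, and it shows that this position takes a group of 3 heavy atoms, with a hydrogen-bond donor and acceptor, without moving the number beyond the scatter. Nothing measured here explains why the read-out holds across this change.

The compounds shown leave open whether an amine, a methyl ester or a longer chain ending in carboxy would read the same at this position. They also leave open whether carboxy on the ring of the ester in compound 3 would behave as it does in compound 4.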